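The source may hold more compounds than are shown below. What is called first, only, known or untested is meant among the compounds shown, and "the series" means these compounds.

Two compounds have a measured lipophilicity so far. Compound 1 `Cc1c(C)c2c(c(C)c1O)CCC(C)(COc1ccc(/C=C3/SC(=O)NC3=O)cc1)O2` gives 5.31 in a physicochemical assay for lipophilicity; on this read-out higher numbers stand for higher lipophilicity and lower numbers for lower lipophilicity. Compound 2 `O=C1NC(=O)C(Cc2ccc(OCC3CCC3)cc2)S1` gives 2.81 in this assay, the lower of the two numbers; compound 1 stands higher by a gap that is beyond the usual scatter. Within the data shown here, no two measured compounds differ in only one place, so no measured step between neighbours is available here.

Compound 3 `O=C1NC(=O)C(Cc2ccccc2)S1` has not yet been measured. It differs from compound 2 in a single place: hydrogen in place of cyclobutylmethoxy on an aromatic carbon. The cyclobutylmethoxy group leaves and only a hydrogen enters on the shared core. On that basis compound 3 is expected to come out lower than compound 2 in this assay, and the step of a number 1.21 log units lower from compound 2 to compound 3 (beyond the scatter) is expected to be downward and clearly larger than the scatter. For compound 3 the estimated value in this assay is 1.6, with a likely range from 1.1 to 2.1.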

Compound 3, partition coefficient: 1.99
Beside the measured number, compound 3's estimate is 0.39 log units below it; the measured number falls inside the stated range.
By their numbers in this assay, from the lowest: compound 3; then compound 2; then compound 1.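

In this assay, among these compounds, replacing cyclobutylmethoxy with hydrogen on the aromatic carbon gives a number 0.82 log units lower from compound 2 to compound 3 (beyond the scatter), the first measured comparison of two compounds that differ in one place. It shows that the read-out at this position depends on which of these two groups is present, as the change exceeds what repeat measurements alone would produce. The data give no explanation for the direction or size of this step.

Going by these compounds, how a small methoxy group, a straight butoxy chain or an amine at this position would compare with cyclobutylmethoxy and hydrogen remains open. Also open, on these data alone, is whether the same replacement would give a step of similar size on a different core, such as the core of compound 1.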